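A few compounds are considered here, and "the series" means these few. Any claim that something is new, unique, unknown or untested is made for them only; others in the source may bear on it.

Measured so far: compound 1 `C=C1C(CC)=C(C#N)C(=O)N1c1cc(Cl)c(Cl)cc1Cl` with 7250 nM; compound 2 `C=C1C(C(C)C)=C(C#N)C(=O)N1c1ccc(Cl)cc1C(C)(C)C` with 42000 nM.

In an assay on isolated protein for binding affinity to ecdysone receptor (Lucilia cuprina), read by fluorescence polarization, with a stated time of 3 h (a higher number here means a weaker inhibitor, a lower number a stronger inhibitor), compound 1 gives 7250 nM, the lower of the two numbers. Compound 2 gives 42000 nM, a gap beyond the scatter, but compound 2 differs from compound 1 in more than one place, so its value cannot be read as a single step. Compound 3 `C=C1C(CC(C)C)=C(C#N)C(=O)N1c1cc(Cl)c(Cl)cc1Cl` is not yet measured. It differs from compound 1 by isopropyl in place of methyl on a saturated chain carbon bound to a double-bonded ring carbon. For the measured compounds named here, no measured pair carries this change alone. The expected step is a 1.5-fold higher number from compound 1 to compound 3 (0.18 log units; within the scatter), a slight weakening that may still lie within the scatter. Compound 3 is estimated at 11000 nM, between 3500 nM and 35000 nM.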

Compound 3, half-maximal inhibitory concentration: 5500 nM
Estimate against measurement, compound 3: 2.0-fold (0.30 log units) above; the range from low to high includes it.
By their numbers in this assay, from the lowest: compounds 3 and 1 (each within the scatter of the next); then compound 2.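

In this assay, isopropyl in place of methyl on a saturated chain carbon bound to a double-bonded ring carbon gives a 1.3-fold lower number from compound 1 to compound 3 (0.12 log units; within the scatter), so ethyl and isobutyl cannot be told apart at this place on the core of compound 1. Compound 2 differs from compound 1 in more than one place and gives no separate reading of this change. No evidence is available that bears on this result.

Still open, as far as these compounds go, is whether a longer chain, or a chain ending in an amine or a carboxylic acid, gives a step beyond the scatter at this place. Also open, from the compounds shown here alone, is whether the same change reads alike on the core of compound 2.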